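The source may hold more compounds than are shown below. What is called first, only, known or untested is meant among the compounds shown, and "the series" means these compounds.

Working notes on the series.

Compound 1 `N#C/C(=C\c1c(F)c(F)c(F)c(F)c1F)C(=O)c1c[nH]c2ccccc12` and compound 2 `COc1ccc(CNC(=O)/C(C#N)=C/c2ccco2)cc1` have been measured in a functional assay on MCF7 cells (Homo sapiens) for inhibition, read by MTT assay, with a stated time of 72 h; a higher number here means a weaker inhibitor of growth, a lower number a stronger inhibitor of growth. Compound 1 gives 13000 nM in this assay, and compound 2 gives 27000 nM. Among the measured compounds shown here, compound 2 thus stands with the highest of the two numbers so far; its nearest neighbour is compound 1, which is beyond the scatter lower in this assay. The two compounds share no single point of difference, so the gap between them is noted as two separate values and nothing more.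

Compound 3 `COc1ccc(CNC(=O)/C(C#N)=C/c2ccc(-c3ccccc3)o2)cc1` has not yet been measured in this assay. Against compound 2 the change is phenyl in place of hydrogen on an aromatic carbon. For the measured compounds named here, no step between measured compounds of this kind is available, so the direction and size of the step from compound 2 to compound 3 rest on the structural change alone.

The expected step in this assay is a 2.3-fold lower number from compound 2 to compound 3 (0.35 log units; beyond the scatter), a moderate move toward a lower number, but not confidently beyond the scatter. For compound 3 the estimated value in this assay is 12000 nM, with a range from 4000 nM to 35000 nM.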

Compound 3, concentration for 50% growth inhibition: 3000 nM
Beside the measured number, compound 3's estimate is 4.0-fold (0.60 log units) above it; measured number below the stated range.
By their numbers in this assay, from the lowest: compound 3; then compound 1; then compound 2.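

Among the compounds shown here, this is the first step that can be read, and it shows that this position responds to substitution: in this assay, phenyl in place of hydrogen on an aromatic carbon, next to the ring oxygen and two ring bonds from the ring atom that bears a large group, gives a 9.0-fold lower number from compound 2 to compound 3 (0.95 log units; beyond the scatter). The entering group is one six-membered aromatic ring of carbon only, with 0 hydrogen-bond donors and 0 hydrogen-bond acceptors, so this step comes with neither added to the structure. Nothing measured here accounts for the size of the step.

For the compounds shown here, the series holds only this one change at this one position, so it remains open whether the lower number goes with phenyl itself or would also follow from a smaller group such as methyl or chlorine, or from a group that carries an amine or a carboxylic acid. As far as these compounds go, with a single pair, it also remains open whether the same change would give a step of similar size on the core of compound 1.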